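The source may report more compounds than this note shows. Statements on the series, on what has been measured and on what is new or still open speak of the compounds shown alone.

Compound 2 `C[C@@H]1CCCN1c1c(C#N)c2c(N)nc(Nc3cn[nH]c3)nc2n1C` gives 6 nM in an assay on isolated protein for inhibition of Leucine-rich repeat serine/threonine-protein kinase 2 (Homo sapiens), read by TR-FRET and LanthaScreen, with stated times of 50 min and 30 min, in the presence of a further agent that is not named here (a higher number here means a weaker inhibitor, a lower number a stronger inhibitor), the lowest of the three numbers in hand. Compound 1 `Cc1c(Nc2nc(N)c3c(C#N)c(N4CCC[C@H]4C)n(C)c3n2)cnn1C` gives 75 nM in this assay, and compound 3 `Cn1c(N2CCCC2)c(C#N)c2c(N)ncnc21` gives 1480 nM. Going by the values given here, the one measured step that compares, from compound 1 to compound 2, swapped 1H-pyrazol-4-yl in for 1,5-dimethyl-1H-pyrazol-4-yl on a nitrogen on an aromatic ring and brought a 13-fold lower number from compound 1 to compound 2 (1.10 log units; beyond the scatter). Compound 4 `Cc1nn(C2COC2)cc1Nc1nc(N)c2c(C#N)c(N3CCC[C@H]3C)n(C)c2n1` differs from compound 2 by 3-methyl-1-(oxetan-3-yl)-1H-pyrazol-4-yl in place of 1H-pyrazol-4-yl on a nitrogen on an aromatic ring. Among the compounds with values here, that earlier step is the only guide, and it shows a substituted pyrazole on this nitrogen going with a higher number, so one expects compound 4 to move upward by less than that, with a 5.8-fold higher number from compound 2 to compound 4 (0.77 log units; beyond the scatter). Compound 4 is therefore estimated at 35 nM, in a range from 10 nM to 150 nM.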

Compound 4, half-maximal inhibitory concentration: 38 nM
Estimate against measurement, compound 4: 1.1-fold (0.04 log units) below; low and high end bracket the measured number.
By their numbers in this assay, from the lowest: compound 2; then compounds 4 and 1 (each within the scatter of the next); then compound 3.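

Across these compounds, a second substituted pyrazole on this nitrogen also goes with a higher number than 1H-pyrazol-4-yl, with a 6.3-fold higher number from compound 2 to compound 4 (0.80 log units; beyond the scatter) in this assay. Exchanging 1,5-dimethyl-1H-pyrazol-4-yl for 3-methyl-1-(oxetan-3-yl)-1H-pyrazol-4-yl gives a 2.0-fold lower number from compound 1 to compound 4 (0.30 log units; within the scatter), so these two substituted pyrazoles cannot be told apart here despite their different substituents. No supporting measurement explains either step. The compounds shown leave open whether the methyl or the oxetan-3-yl group carries the step from compound 2 to compound 4. They also leave open how a pyrazole bearing an amine or a longer chain would read.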